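The source may report more compounds than this note shows. Statements on the series, on what has been measured and on what is new or still open speak of the compounds shown alone.

Measured so far in a functional assay on the whole organism for antagonist activity, with Mus musculus as the target; a higher number here means that more compound is needed for the effect, a lower number that less compound is needed:
compound 1, `CCCCCCN1CCC(C(=O)Nc2cc(Cl)c(N)cc2OC)CC1`: > 10 mg/kg, a limit of the assay, not a number.
compound 2, `COc1cc(N)c(Cl)cc1NC(=O)C1CCN(C2CCCC2)CC1`: > 10 mg/kg, again a limit of the assay.
compound 3, `COc1cc(N)c(Cl)cc1NC(=O)C1CCN(Cc2ccccc2Cl)CC1`: > 4 mg/kg, also a limit of the assay.

Compound 1 thus stands only at a limit in this assay; no measured number places it against compound 2 or compound 3. Two of the three values sit together at the limit of > 10 mg/kg in this assay, at which 2 of the 3 values shown sit, the remaining one at the limit of > 4 mg/kg in this assay, at which 1 of the 3 values shown sits.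

The next compound is compound 4, `COc1cc(N)c(Cl)cc1NC(=O)C1CCN(CC2CCCCC2)CC1`. Against compound 1 the change is cyclohexyl in place of pentyl on a saturated chain carbon bound to an amine nitrogen in a ring.

The measured steps at the same amine nitrogen are all unreadable: a step that the two limits leave unreadable from compound 1 to compound 2, a step that the two limits leave unreadable from compound 1 to compound 3 and a step that the two limits leave unreadable from compound 2 to compound 3. None of them yields a size or a direction, so nothing in the series allows a step beyond the scatter to be expected for compound 4 in this assay, and nothing rules one out. The working assumption is that compound 4 stays where the others are seen, which means a further limit is the likeliest outcome.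

Compound 4 is thus expected at about 15 mg/kg, with a range from 4 mg/kg to 60 mg/kg. The expected step is a step that the limit leaves unreadable from compound 1 to compound 4.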

Compound 4, dose for half-maximal effect: 2.9 mg/kg
Estimate against measurement, compound 4: 5.2-fold (0.71 log units) above; measured number below the stated range.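

In this assay compound 4 is the only compound shown that gives a number rather than a limit, so the group on the amine nitrogen in a ring now has a readable effect. Cyclohexyl in place of pentyl on the saturated chain carbon gives an at least 3.4-fold lower number from compound 1 to compound 4 (0.53 log units; beyond the scatter), and cyclohexylmethyl in place of cyclopentyl on the amine nitrogen gives an at least 3.4-fold lower number from compound 2 to compound 4 (0.53 log units; beyond the scatter), so neither hexyl nor cyclopentyl matches cyclohexylmethyl here. Cyclohexyl in place of 2-chlorophenyl gives only an at least 1.3-fold lower number from compound 3 to compound 4 (0.13 log units; that floor lies within the scatter), which does not separate these two groups.

As far as these compounds go, the steps among compound 1, compound 2 and compound 3 cannot be read, and the full size of each new step stays open, since each rests on a limit: the limit of > 10 mg/kg in this assay, at which 2 of the 4 values shown sit. Also open in this assay is whether a cyclohexyl ring on a longer chain, or an unsubstituted benzyl on the amine nitrogen, would hold this level.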